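The source may hold more compounds than are shown below. What is called first, only, known or untested is meant among the compounds shown, and "the series" means these compounds.

Working notes on a short series in a functional assay on NCI/ADR cells (Homo sapiens) for inhibition, read by sulforhodamine B assay, with a stated time of 48 h; a higher number here means a weaker inhibitor of growth, a lower number a stronger inhibitor of growth. Compound 1 `O=C1C=COC(/C=C/c2ccccc2)C1` gives 105 uM. Compound 2 `COc1ccc(/C=C/C2CC(=O)C=CO2)cc1` carries the change methoxy in place of hydrogen on an aromatic carbon and gives 239 uM; the step of a 2.3-fold higher number from compound 1 to compound 2 (0.36 log units; beyond the scatter) is modest but beyond the scatter. Compound 3 `COc1ccc(/C=C/c2cc(=O)cco2)cc1` has a core that differs from that of compound 1 in a way not broken down here. In this assay compound 3 gives 310 uM; against compound 2 its value lies within the scatter, against compound 1 beyond it. Compound 4 `COc1ccc(/C=C/c2cc(=O)cco2)cc1OC` is not yet measured; it differs from compound 3 by methoxy in place of hydrogen on an aromatic carbon. This is the same kind of change as that from compound 1 to compound 2, but not the same: in compound 2 the entering methoxy sits para to a group of 9 heavy atoms, whereas in compound 4 it sits ortho to a methoxy group and meta to a group of 9 heavy atoms. For compound 4 the expected step is a 1.5-fold higher number from compound 3 to compound 4 (0.19 log units; within the scatter), which rests only on the measured step of a 2.3-fold higher number from compound 1 to compound 2 (0.36 log units; beyond the scatter). Compound 4 is therefore estimated at 480 uM, most likely between 250 uM and 900 uM.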

Compound 4, concentration for growth inhibition (reported as GI): 408 uM
Estimate against measurement, compound 4: 1.2-fold (0.07 log units) above, and the stated range covers the measured number.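

In this assay, methoxy in place of hydrogen on the aromatic carbon gives a 1.3-fold higher number from compound 3 to compound 4 (0.12 log units; within the scatter), and the gap between this step and the earlier one does not exceed what two such steps can show by scatter alone: the same change on two cores in this assay, a 2.3-fold higher number (0.36 log units; beyond the scatter) from compound 1 to compound 2 and a 1.3-fold higher number (0.12 log units; within the scatter) from compound 3 to compound 4, 1.7-fold (0.24 log units) apart, within the scatter of two such steps. The two results are therefore compatible with a change that carries across the two cores, but only the earlier step lies beyond the scatter, so a shared shift of the same size on both cores is not established. The evidence also rests on a single pair per core, and the two pairs differ in place as well as in core: in compound 4 the methoxy enters ortho to a methoxy group and meta to a group of 9 heavy atoms, so the effects of core and place cannot be separated.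

The aromatic ring in these compounds carries only hydrogen or methoxy. As far as these compounds go, how an amine, a carboxylic acid or a longer chain such as butoxy would behave on either core remains open.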